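A few compounds are considered here, and "the series" means these few. Any claim that something is new, unique, unknown or untested is made for them only; others in the source may bear on it.

Measured so far:
- compound 1, `Cc1cccc(Cn2c(CN3CCN(C(=O)CC(C)C)CC3)nc3ccccc32)c1`, 71.4% 
- compound 2, `CC(C)CCn1c(CN2CCN(C(=O)C3CC3)CC2)nc2ccccc21`, 70% 
- compound 3, `Cc1cccc(Cn2c(CN3CCN(C(=O)c4ccco4)CC3)nc3ccccc32)c1`, 73.2% 

These three compounds share one core and were all tested in an assay on isolated protein for inhibition of aldehyde dehydrogenase 1A1 (Homo sapiens), read by spectrophotometry, tested at 10 uM; on this read-out higher numbers stand for more inhibition at the one concentration tested (going by the name of the read-out) and lower numbers for less inhibition. On the numbers shown, compound 3 gives the highest reading, but compound 1 sits only a little lower at 71.4% and compound 2 at 70%, and both gaps fall within the scatter, so the three cannot be told apart. Within the data shown here, the one step between single-change neighbours, a number 1.8 percentage points higher from compound 1 to compound 3 (within the scatter), also lies within the scatter.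

Compound 4, `CC(C)CCn1c(CN2CCN(C(=O)c3ccco3)CC2)nc2ccccc21`, has not yet been measured. It differs from compound 3 as follows: isobutyl in place of 3-methylphenyl on a saturated chain carbon bound to an aromatic nitrogen. Among the measured compounds shown here, no measured step covers this change. Compound 2 carries the isopentyl chain at the same place but also another group on the carbonyl, and its value of 70% is close to that of compound 3. For the measured compounds named here, with every step so far inside the scatter, the change from compound 3 to compound 4 is expected to give no step beyond the scatter, a number 3.2 percentage points lower from compound 3 to compound 4 (within the scatter). Compound 4 is therefore estimated at 70%, with a range from 58% to 82%.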

Compound 4, a percentage reported as inhibition, at one concentration (the size of the read-out at that concentration, not a potency): 42.1%
Beside the measured number, compound 4's estimate is 27.9 percentage points above it, and the stated range ends above it.
By their numbers in this assay, from the lowest: compound 4; then compounds 2, 1 and 3 (each within the scatter of the next).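

At the place on a saturated chain carbon bound to an aromatic nitrogen, swapping 3-methylbenzyl for isopentyl clearly matters in this assay: the result is a number 31.1 percentage points lower from compound 3 to compound 4 (beyond the scatter), so this position is not as forgiving as the earlier, closely grouped numbers suggested. Among these compounds, the group on the carbonyl can matter too, since with the isopentyl chain in place, furan-2-yl instead of cyclopropyl gives a number 27.9 percentage points lower from compound 2 to compound 4 (beyond the scatter), while the one earlier carbonyl change, furan-2-yl for isobutyl, gave only a number 1.8 percentage points higher from compound 1 to compound 3 (within the scatter). No measurement shown offers a reason for either drop.

Still open, as far as these compounds go, is whether the reading depends on the aromatic ring itself, which a plain benzyl or a cyclohexylmethyl group at this position could help to separate. From the compounds shown here alone, it also remains unknown how cyclopropyl on the carbonyl would read alongside 3-methylbenzyl.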